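Swapping a Methyl Aryl for a Nitro Aryl: Cytotoxicity Outlook

A few compounds are considered here, and "the series" means these few. Any claim that something is new, unique, unknown or untested is made for them only; others in the source may bear on it.

Of the compounds shown here, three sharing one core have been tested in an ADME assay on HepG2 cells (Homo sapiens) for cytotoxicity, read by MTT assay, with a stated time of 72 h; on this read-out lower numbers stand for higher toxicity in this test and higher numbers for lower toxicity in this test. Compound 1, `Cc1ccc(-c2ccc(C3(C)CC(S(=O)(=O)c4ccc(F)cc4)=C(c4ccc(/C(N)=N\O)cc4)O3)cc2)cc1`, gives 13700 nM in this assay. Compound 3, `N/C(=N/O)c1ccc(C2=C(S(=O)(=O)c3ccc(F)cc3)CC(c3ccccc3)(c3ccccc3)O2)cc1`, gives 19200 nM, and compound 2, `CC1(Cc2ccccc2)CC(S(=O)(=O)c2cccc(C(F)(F)F)c2)=C(c2ccc(/C(N)=N\O)cc2)O1`, gives 33400 nM. Compound 1 thus has the lowest of the three numbers, but the value of compound 3 lies within the usual scatter of it, so those two cannot be told apart; only the value of compound 2 stands beyond the scatter, on the higher side.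

The next compound, compound 4, is `CC1(c2ccc(-c3cccc([N+](=O)[O-])c3)cc2)CC(S(=O)(=O)c2ccc(F)cc2)=C(c2ccc(/C(N)=N\O)cc2)O1`. It differs from compound 1 in one place: 3-nitrophenyl in place of 4-methylphenyl on an aromatic carbon. Among the compounds with values here, nothing measured so far reports what this particular exchange does in this assay, since no pair of measured compounds differs in exactly this way.

With only that to go on, the step from compound 1 to compound 4 is expected to be small, likely staying within the scatter and in no firm direction, giving a 1.1-fold higher number from compound 1 to compound 4 (0.04 log units; within the scatter). Compound 4 is therefore estimated at 15000 nM in this assay, with a range from 6000 nM to 38000 nM.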

Compound 4, half-maximal cytotoxic concentration: > 50000 nM
Compound 4 was reported as a limit (the forecaster's own chance of this, stated with the estimate: 10%); middle value at least 3.3-fold (0.52 log units) from the limit.
By their numbers in this assay, from the lowest: compounds 1, 3 and 2 (each within the scatter of the next, the first and the last beyond it). At a limit, above all of these: compound 4.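

In this assay, compound 4 gives > 50000 nM, which is a limit of the assay and not an exact number. Placing 3-nitrophenyl in place of 4-methylphenyl on this aromatic carbon gives an at least 3.6-fold higher number from compound 1 to compound 4 (0.56 log units; beyond the scatter), the first step in this series that can be tied to one change, and it shows that the group at this position can move the read-out beyond the scatter, towards lower toxicity in this test. The step gives only a minimum size, and its true size cannot be read, as compound 4 stands at the top of what the test reports: the limit of > 50000 nM in this assay, at which 1 of the 4 values shown sits.

This single pair cannot tell whether the nitro group or its different place on the phenyl ring matters, and a 4-nitrophenyl or a 3-methylphenyl group at the same carbon would begin to separate the two. Going by these compounds, it also remains open whether other groups on that phenyl ring, such as a 3-aminophenyl or a 3-carboxyphenyl group, would shift the number in the same direction, and why the exchange has this effect cannot be told from these data.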